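The compounds below may be only part of what the source reports. "The series", "measured", "known", "first", "only" and "open" are said of these compounds alone.

Compound 1, `CC(C)c1ccc(S(C)(=O)=O)cc1C#Cc1cc(C#N)ccc1OCC(=O)O`, gives 12 nM in an assay on CHO cells for displacement of a labelled ligand from prostaglandin D2 receptor 2 (Homo sapiens), read by scintillation counting; on this read-out higher numbers stand for weaker inhibition and lower numbers for stronger inhibition.
Compound 2, `Cc1ncccc1C#Cc1cc(Cl)ccc1OCC(=O)O`, gives 143 nM.
Compound 3, `Cc1ccc(S(=O)(=O)CCO)cc1C#Cc1cc(Cl)ccc1OCC(=O)O`, gives 19 nM.

Compound 3 has the second highest of the three numbers. Its nearest neighbour is compound 1, and the gap between them lies within the scatter of repeated measurements, so the two cannot be told apart. Its furthest neighbour is compound 2, whose number is higher by a gap that lies beyond the scatter.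

Compound 4, `Cc1ccc(S(=O)(=O)N2CCCCC2C)cc1C#Cc1cc(Cl)ccc1OCC(=O)O`, is not yet measured. It differs from compound 3 in one place: 2-methylpiperidin-1-yl in place of 2-hydroxyethyl on a sulfonyl sulfur. Going by the values given here, no measured pair shows this exact change, so its effect has to be judged from what is known. Compound 1 carries a different group on its sulfonyl sulfur and gives 12 nM, within the scatter of compound 3, which suggests that the group on this sulfur may be changed without a large shift. The step from compound 3 to compound 4 is therefore expected to be small, a 1.2-fold higher number from compound 3 to compound 4 (0.06 log units; within the scatter), with no clear direction beyond the scatter. Compound 4 is estimated to give 22 nM, in a range from 6 nM to 80 nM.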

Compound 4, inhibition constant: 1.9 nM
Compound 4: middle estimate off by 12-fold (1.06 log units), on the high side, outside the stated range (below it).
By their numbers in this assay, from the lowest: compound 4; then compounds 1 and 3 (each within the scatter of the next); then compound 2.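

The group on the sulfonyl sulfur turns out to matter a great deal in this assay: putting 2-methylpiperidin-1-yl in place of 2-hydroxyethyl gives a 10-fold lower number from compound 3 to compound 4 (1.00 log units; beyond the scatter) and so this position can respond strongly to change. Several things change together in this one step, since the entering group brings more heavy atoms, a six-membered non-aromatic ring and 0 hydrogen-bond donors where the leaving group has 1, and the step alone cannot separate them. No measurement at hand accounts for the size of this step.

From the compounds shown here alone, what a plain piperidin-1-yl, without its methyl, or an open-chain dimethylamino group would give on this sulfur remains open. Also open, going by these compounds, is whether the same change would give a step of similar size on the core of compound 1.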